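Substituent on the aromatic nitrogen: cytotoxicity working notes

A few compounds are considered here, and "the series" means these few. Any claim that something is new, unique, unknown or untested is made for them only; others in the source may bear on it.

Measured so far in an ADME assay on BV-2 cells (Mus musculus) for cytotoxicity, read by MTT assay, with a stated time of 48 h, tested at 40 uM; on this read-out lower numbers stand for a stronger effect and higher numbers for a weaker effect at the one concentration tested:
- compound 1 `O=C1COCCN1c1ccc(/N=C\c2c[nH]c3ccccc23)cc1` gives 105%
- compound 2 `Cc1ccc(S(=O)(=O)n2cc(/C=N\c3ccc(N4CCOCC4=O)cc3)c3ccccc32)cc1` gives 58.1%

Within the data shown here, compound 2 stands lowest of the two numbers in this assay; its nearest neighbour is compound 1, and the one step recorded, a number 46.9 percentage points lower from compound 1 to compound 2 (beyond the scatter), is large and beyond the scatter.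

Compound 3 `O=C1COCCN1c1ccc(/N=C\c2cn(C(=O)c3ccccc3)c3ccccc23)cc1` is not yet measured. It differs from compound 2 as follows: benzoyl in place of (4-methylphenyl)sulfonyl on an aromatic nitrogen. Among the measured compounds shown here, no measured pair shows this exchange directly. For the measured compounds named here, the only step that bears on it is the one from compound 1 to compound 2, which shows that placing a large group on this aromatic nitrogen goes with a strong fall in this assay; compound 3 keeps a large group there, so a value near compound 2 is expected, with some allowance for the smaller group, giving an expected step of a number 9.9 percentage points higher from compound 2 to compound 3 (within the scatter). The estimate for compound 3 is therefore 68%, with a range from 45% to 95%.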

Compound 3, a percentage reported as activity, at one concentration (the size of the read-out at that concentration, not a potency): 72.6%
The estimate for compound 3 lay 4.6 percentage points below the measured number, and the stated range covers the measured number.
By their numbers in this assay, from the lowest: compound 2; then compound 3; then compound 1.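

In this assay, the aromatic nitrogen does not simply respond to the presence of any large group, as the exchange of (4-methylphenyl)sulfonyl for benzoyl gives a number 14.5 percentage points higher from compound 2 to compound 3 (beyond the scatter). The fall seen on replacing hydrogen is also not confined to (4-methylphenyl)sulfonyl, since benzoyl in place of hydrogen gives a number 32.4 percentage points lower from compound 1 to compound 3 (beyond the scatter), so among these three compounds the read-out depends on which group is present as well as on whether the position is substituted. Nothing available here explains the difference between the two groups.

From the compounds shown here alone, it remains open whether a small acetyl or methanesulfonyl group on this nitrogen would give a fall of similar size, and whether a benzyl group, which has neither carbonyl nor sulfonyl, would do so. With one concentration per compound, these numbers also leave the concentration dependence of each fall open.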